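A few compounds are considered here, and "the series" means these few. Any claim that something is new, unique, unknown or untested is made for them only; others in the source may bear on it.

Working notes on the series. In a functional assay on HL-60 cells (Homo sapiens) for cytotoxicity, read by MTT assay, with a stated time of 48 h (a lower number here means a stronger inhibitor, a higher number a weaker inhibitor), compound 1 `Fc1cccc(-c2nc(Nc3ccccc3)c3cc(F)ccc3n2)c1` gives 48300 nM. Compound 2 `Fc1cccc(Nc2nc(-c3cccc(F)c3)nc3ccc(F)cc23)c1` gives 43100 nM in this assay. For compound 3 `Fc1cccc(-c2nc(Nc3ccc(Br)cc3)c3cc(F)ccc3n2)c1` this assay reports only a limit, > 50000 nM. Compound 3 therefore stands close to compound 1 and compound 2, since an at least 1.0-fold higher number from compound 1 to compound 3 (0.01 log units; that floor lies within the scatter) and an at least 1.1-fold higher number from compound 2 to compound 3 (0.06 log units; that floor lies within the scatter) are both within the scatter, as is a 1.1-fold lower number from compound 1 to compound 2 (0.05 log units; within the scatter). The position of compound 3 is set by the limit of > 50000 nM in this assay, at which 1 of the 3 values shown sits, and not by a number.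

Compound 4 `Nc1ccccc1Nc1nc(-c2cccc(F)c2)nc2ccc(F)cc12` differs from compound 3 by 2-aminophenyl in place of 4-bromophenyl on a nitrogen on an aromatic ring. Within the data shown here, none of the measured steps covers this change. The nearest comparison, an at least 1.1-fold higher number from compound 2 to compound 3 (0.06 log units; that floor lies within the scatter), exchanged one substituted phenyl for another on the same nitrogen and stayed within the scatter, and the other two steps also stayed within the scatter. Compound 3 itself is known only as a limit, so any step from it can be read only from that floor. The step expected from this change, an at least 1.1-fold lower number from compound 3 to compound 4 (0.04 log units; that floor lies within the scatter), is accordingly small, with no direction claimed beyond the scatter. Compound 4 is expected at 45000 nM, within a range from 15000 nM to 150000 nM, and there is a real chance that this assay again returns only a limit.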

Compound 4, half-maximal inhibitory concentration: 41300 nM
For compound 4 the middle estimate is 1.1-fold (0.04 log units) above the measured one; low and high end bracket the measured number.
By their numbers in this assay, from the lowest: compounds 4, 2 and 1 (each within the scatter of the next). At a limit, above all of these: compound 3.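

Working from this assay, the amino group of the 2-aminophenyl ring is the first change on this nitrogen's phenyl ring that brings in a hydrogen-bond donor and acceptor, and the number stays in place: a 1.2-fold lower number from compound 1 to compound 4 (0.07 log units; within the scatter), and a 1.0-fold lower number from compound 2 to compound 4 (0.02 log units; within the scatter). Amino on this ring therefore joins the 3-fluorophenyl change in staying within the scatter, so across the phenyl groups with a readable number, the identity of the substituent on this ring has no visible effect on the number in this series. The comparison with the 4-bromophenyl compound is weaker, as an at least 1.2-fold lower number from compound 3 to compound 4 (0.08 log units; that floor lies within the scatter) gives only a floor resting on a limit: the limit of > 50000 nM in this assay, at which 1 of the 4 values shown sits.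

The compounds shown leave open whether any change on this nitrogen can move the number beyond the scatter, since every readable step so far stays within it. A carboxylic acid on the phenyl ring, a 4-aminophenyl group, or a longer alkyl chain in place of the phenyl ring would test this, as would an amine on the core's other phenyl ring, the 3-fluorophenyl group.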